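The compounds below may be only part of what the source reports. "The series", "measured", "known", "first", "only" and "open" are said of these compounds alone.

Compound 1 `CCCN(CCC)c1cc(C)nc2c(-c3c(C)cc(N(C)C)nc3C)c(C)nn12` gives 5.2 nM in an assay on CHO cells for binding affinity to corticotropin-releasing factor receptor 1 (Homo sapiens); on this read-out higher numbers stand for weaker inhibition and lower numbers for stronger inhibition. Compound 3 `CCCN(CCC)c1cc(C)nc2c(-c3cnc(C)cc3C)c(C)nn12` gives 7.3 nM in this assay, a value within the usual scatter of that of compound 1, while compound 2 `CCCN(CCC)c1cc(C)nc2c(-c3ccc(C)nc3)c(C)nn12` gives 21 nM. The step of a 2.9-fold higher number from compound 3 to compound 2 (0.46 log units; beyond the scatter) rests on (hydrogen in place of methyl on an aromatic carbon). The difference between the cores of compound 1 and compound 3 is not broken down here.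

Compound 4 `CCCN(CCC)c1cc(C)nc2c(-c3c(C)cc(N(C)C)nc3C)cnn12` has not yet been measured; it differs from compound 1 by hydrogen in place of methyl on an aromatic carbon. This is the same kind of change as that from compound 3 to compound 2, but its place differs: in compound 4 the change sits on an aromatic carbon of a five-membered aromatic ring with 2 nitrogen, part of a fused or bridged system of two rings, next to the ring nitrogen and next to the ring atom that bears a large group, whereas in compound 2 it sits on a six-membered aromatic ring with 1 nitrogen, ortho to a large group, meta to a methyl group and opposite the ring nitrogen. On the measured pair the change gave a 2.9-fold higher number from compound 3 to compound 2 (0.46 log units; beyond the scatter). For compound 4 a step of similar size is expected, a 2.9-fold higher number from compound 1 to compound 4 (0.46 log units; beyond the scatter). Compound 4 is therefore estimated at 15 nM, within a range from 5 nM to 45 nM.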

Compound 4, inhibition constant: 20 nM
Compound 4: the middle estimate sits 1.3-fold (0.12 log units) below what was measured, within the range that was stated.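

In this assay, hydrogen in place of methyl on an aromatic carbon gives a 3.8-fold higher number from compound 1 to compound 4 (0.59 log units; beyond the scatter). Set beside the earlier step, the change keeps much the same size on the two cores, although it sits on a different ring in each: the same change on two cores in this assay, a 2.9-fold higher number (0.46 log units; beyond the scatter) from compound 3 to compound 2 and a 3.8-fold higher number (0.59 log units; beyond the scatter) from compound 1 to compound 4, 1.3-fold (0.13 log units) apart, within the scatter of two such steps With only two pairs, this shows agreement for these cores and these two places, not a rule for the series, and it gives no reason for the size of either step.

The compounds shown leave open what an ethyl group, a chlorine atom or a methoxy group would give in place of the methyl on the five-membered aromatic ring. They also leave open whether the step found on one ring would hold on the other within a single core.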